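The source may hold more compounds than are shown below. What is called first, only, known or untested is meant among the compounds shown, and "the series" means these compounds.

Measured compounds:
- compound 1 `CCc1ccc(NC(=O)C2CCN(C/C=C/c3ccccc3)CC2)cc1`: 23300 nM
- compound 2 `CCCCCc1ccc(NC(=O)C2CCN(C/C=C/c3ccccc3)CC2)cc1`: 2890 nM
- compound 3 `O=C(Nc1cccc(Cl)c1)C1CCN(C/C=C/c2ccccc2)CC1`: 20000 nM

Going by the values given here, in a functional assay on HepG2 cells (Homo sapiens) for inhibition, read by MTT assay, with a stated time of 72 h (a higher number here means a weaker inhibitor, a lower number a stronger inhibitor), compound 1 gives the highest of the three numbers; compound 3 sits a 1.2-fold lower number from compound 1 to compound 3 (0.07 log units; within the scatter), within the scatter, while compound 2 sits an 8.1-fold lower number from compound 1 to compound 2 (0.91 log units; beyond the scatter), the only step beyond it. Compound 4 `N#Cc1ccc(NC(=O)C2CCN(C/C=C/c3ccccc3)CC2)cc1` is not yet measured. It differs from compound 1 by cyano in place of ethyl on an aromatic carbon. Among the compounds with values here, no measured step touches this change directly: the step from compound 1 to compound 2 lengthens the chain that compound 4 removes, and the step from compound 1 to compound 3 swaps the whole 4-ethylphenyl for 3-chlorophenyl without a marked effect. Lengthening helped; the one change that did not lengthen stayed flat. For compound 4 the expectation is therefore a step of a 1.3-fold higher number from compound 1 to compound 4 (0.11 log units; within the scatter), not beyond the scatter. Compound 4 is expected to give 30000 nM in this assay, with a range of 9000 nM to 100000 nM.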

Compound 4, half-maximal inhibitory concentration: 38300 nM
The estimate for compound 4 lay 1.3-fold (0.11 log units) below the measured number, within the range that was stated.
By their numbers in this assay, from the lowest: compound 2; then compounds 3, 1 and 4 (each within the scatter of the next).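

In this assay, cyano on this aromatic carbon brings a hydrogen-bond acceptor and a triple bond that ethyl lacks, yet the step stays within the scatter: a 1.6-fold higher number from compound 1 to compound 4 (0.22 log units; within the scatter). The 4-cyanophenyl and 3-chlorophenyl amides also cannot be told apart, with a 1.9-fold higher number from compound 3 to compound 4 (0.28 log units; within the scatter). Among the groups shown on this carbon, pentyl alone stands apart from cyano, with a 13-fold higher number from compound 2 to compound 4 (1.12 log units; beyond the scatter), so ethyl and cyano sit together and the only step beyond the scatter at this position involves the longer chain.

No measurement available here bears on the reason for these numbers.

On these data alone, whether a chain longer than pentyl moves the number further remains open. So does whether an amine or a carboxylic acid on this carbon would depart from compound 1.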